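The compounds below may be only part of what the source reports. "The series", "measured", "known", "first", "only" and "open" are said of these compounds alone.

Measured so far:
- compound 1, `CCOC(=O)C1=C(C)NC(C)=C(C(=O)OCC)C1c1ccc(OCC(=O)NCc2ccccc2)cc1`: 31.1%
- compound 2, `CCOC(=O)C1=C(C)NC(C)=C(C(=O)OCC)C1c1ccc(OCC(=O)Nc2c(C)cccc2C)cc1`: 53.9%
- compound 3, `CCOC(=O)C1=C(C)NC(C)=C(C(=O)OCC)C1c1ccc(OCC(=O)NNC(=O)c2ccc(C)cc2)cc1`: 47.3%

All three share one core and differ only in the group on an amide-type nitrogen. In a functional assay on the whole organism (strain Wistar) for inhibition, with Rattus norvegicus as the target, read by paw edema, with stated times of 30 min and 3 h, at a dose of 20 mg/kg (on this read-out lower numbers stand for less inhibition and higher numbers for more inhibition at the one dose given (going by the name of the read-out)), compound 2 gives the highest of the three numbers; the gap to compound 3 is within the scatter, while the step of a number 22.8 percentage points higher from compound 1 to compound 2 (beyond the scatter) lies beyond it, so compound 2 is only clearly set apart from compound 1.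

Compound 4, `CCOC(=O)C1=C(C)NC(C)=C(C(=O)OCC)C1c1ccc(OCC(=O)NNC(=O)c2cccs2)cc1`, is not yet measured. It differs from compound 2 as follows: ((thiophen-2-yl)carbonyl)amino in place of 2,6-dimethylphenyl on an amide-type nitrogen. The closest measured comparison is the step of a number 6.6 percentage points lower from compound 2 to compound 3 (within the scatter), where a related carbonylamino group also took the place of 2,6-dimethylphenyl and the number barely moved. The step of a number 16.2 percentage points higher from compound 1 to compound 3 (beyond the scatter) shows such a carbonylamino group clearly above benzyl.

On this basis compound 4 is expected to land close to compound 2, with an estimated step of a number 7.9 percentage points lower from compound 2 to compound 4 (within the scatter), within the scatter. The estimate for compound 4 is 46%, in the range 33% to 59%.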

Compound 4, a percentage reported as inhibition, in the whole organism at one dose (the size of the read-out at that dose, not a potency): 61.1%
Beside the measured number, compound 4's estimate is 15.1 percentage points below it, and the stated range ends below it.
By their numbers in this assay, from the lowest: compound 1; then compounds 3, 2 and 4 (each within the scatter of the next, the first and the last beyond it).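

In this assay, thiophen-2-yl in place of 4-methylphenyl on a carbonyl carbon gives a number 13.8 percentage points higher from compound 3 to compound 4 (beyond the scatter) and so shows that the ring carried by the carbonylamino group can shift the number, which one such group alone could not show. Among the compounds shown here, on the amide-type nitrogen, ((thiophen-2-yl)carbonyl)amino and 2,6-dimethylphenyl cannot be told apart, with a number 7.2 percentage points higher from compound 2 to compound 4 (within the scatter) as the step, while the step from benzyl widens to a number 30 percentage points higher from compound 1 to compound 4 (beyond the scatter) and leaves benzyl as the one clearly separated group in this set. Nothing shown here gives a reason for these steps.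

Going by these compounds, it remains open whether a furan-2-yl, a cyclohexyl or a plain methyl on the same carbonyl would keep this level. A carboxylic acid or an amine at the end of a longer chain on that nitrogen is also untested in the compounds shown.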